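The compounds below may be only part of what the source reports. "The series", "measured", "known", "first", "only" and "open" are said of these compounds alone.

In a functional assay on HL-60 cells (Homo sapiens) for antiproliferative activity, read by MTT assay, with a stated time of 72 h (on this read-out higher numbers stand for weaker inhibition and lower numbers for stronger inhibition), compound 1 `CC(=O)Oc1cccc(N2C(=O)/C(=C/N3N=C(c4ccccc4)CC3c3ccccc3O)SC2=S)c1` gives 118 nM, and compound 2 `CC(=O)Oc1ccc(N2C(=O)/C(=C/N3N=C(c4ccccc4)CC3c3ccccc3O)SC2=S)cc1` gives 9400 nM. Compound 3 `CCOC(=O)CCN1C(=O)/C(=C/N2N=C(c3ccccc3)CC2c2ccccc2O)SC1=S` reaches only a limit of the assay, > 10000 nM. Of the two numbers shown, compound 2 therefore has the higher one; the step of an 80-fold higher number from compound 1 to compound 2 (1.90 log units; beyond the scatter) and the step of an at least 84-fold higher number from compound 1 to compound 3 (1.92 log units; beyond the scatter) both go well beyond the scatter, while the step of an at least 1.0-fold higher number from compound 2 to compound 3 (0.02 log units; that floor lies within the scatter) does not. Compound 4 `CC(=O)Oc1ccc(N2C(=O)/C(=C/N3N=C(c4ccc5ccccc5c4)CC3c3ccccc3O)SC2=S)cc1` differs from compound 2 by naphthalen-2-yl in place of phenyl on a carbon with a double bond to nitrogen. All three measured steps alter the group on the amide-type nitrogen, none the phenyl on the carbon with a double bond to nitrogen, so none of them bears directly on this change. He expects no step beyond the scatter, a 1.2-fold lower number from compound 2 to compound 4 (0.07 log units; within the scatter), and estimates compound 4 at 8000 nM, between 2000 nM and 30000 nM.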

Compound 4, half-maximal inhibitory concentration: 500 nM
Compound 4: middle estimate off by 16-fold (1.20 log units), on the high side, outside the stated range (below it).
By their numbers in this assay, from the lowest: compound 1; then compound 4; then compound 2. At a limit, above all of these: compound 3.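

In this assay, among the compounds shown here, the swap of phenyl for naphthalen-2-yl gives a 19-fold lower number from compound 2 to compound 4 (1.27 log units; beyond the scatter), so the carbon with a double bond to nitrogen also moves the read-out, which the earlier compounds, all with phenyl there, could not show. The group on the amide-type nitrogen is thus not the only place that matters. Nothing given here accounts for this step.

As far as these compounds go, whether naphthalen-2-yl brings a similar change with the 3-acetoxyphenyl of compound 1 stays open. So does how a methyl group or a phenyl carrying an amine would behave at this position.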